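This account rests on a few compounds, and the source may have more. Where it says the series, first, only, none or still open, it means among the compounds named here.

Compound 1 `COc1ncnc2c1c(I)cn2[C@@H]1O[C@H](CO)[C@@H](O)[C@H]1O`: 14800 nM
Compound 2 `CNc1ncnc2c1c(-c1cccs1)cn2[C@@H]1O[C@H](CO)[C@@H](O)[C@H]1O`: > 20000 nM
Compound 3 `CNc1ncnc2c1c(-c1ccoc1)cn2[C@@H]1O[C@H](CO)[C@@H](O)[C@H]1O`: > 20000 nM

In a functional assay on K562 cells (Homo sapiens), read by MTT assay, with a stated time of 72 h (a higher number here means a weaker inhibitor, a lower number a stronger inhibitor), compound 1 gives 14800 nM. Compound 2 stands at the limit of the assay, > 20000 nM, which is a limit and not a number. Compound 3 stands at the same limit, > 20000 nM, again a limit rather than a number. This is where compound 3 stands: of the three values shown, it shares the limit with one other compound, and only compound 1 has a number. For the measured compounds named here, the single step between measured compounds, a step that the two limits leave unreadable from compound 2 to compound 3, cannot be read because of the limit of > 20000 nM in this assay, at which 2 of the 3 values shown sit.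

Compound 4 `CNc1ncnc2c1c(I)cn2[C@@H]1O[C@H](CO)[C@@H](O)[C@H]1O` differs from compound 3 by iodo in place of furan-3-yl on an aromatic carbon. No measured step covers this change; the one step shown is unreadable. Compound 1 also carries the iodo group and gives a number in this assay, and compound 4 is its methylamino counterpart. On that basis compound 4 is expected to give 15000 nM in this assay, with a range from 5000 nM to 40000 nM. The step this estimate implies, an at least 1.3-fold lower number from compound 3 to compound 4 (0.12 log units; that floor lies within the scatter), is expected to be modest and may again end at a limit.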

Compound 4, half-maximal inhibitory concentration: > 20000 nM
Compound 4: only a limit was reported; the forecaster's own chance of this, stated with the estimate: 35%; at least 1.3-fold (0.12 log units) between middle value and limit.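

In this assay compound 4 also gives only a limit, > 20000 nM, so iodo on this aromatic carbon yields no number when methylamino is present, and the steps to compound 4 from compound 2 and compound 3 cannot be read: the limit of > 20000 nM in this assay, at which 3 of the 4 values shown sit.

For the compounds shown here, the one readable step concerns a different place, with methylamino in place of methoxy on an aromatic carbon and the iodo group kept: it is an at least 1.3-fold higher number from compound 1 to compound 4 (0.13 log units; that floor lies within the scatter), so these compounds do not settle whether this exchange changes the result. Swapping a five-membered aromatic ring for a single iodine atom therefore gives no readable gain in this series, and the only number among the four values remains that of compound 1, 14800 nM.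

On these data alone, how far compound 2, compound 3 and compound 4 lie beyond the limit stays open, so no order can be given among them. As far as these compounds go, it also stays open whether a plain amino group in place of methylamino, or an ethynyl group in place of iodo, would give a number in this assay.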